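From benzyl to carboxymethyl on a shared core

The compounds below may be only part of what the source reports. "The series", "measured", "known", "first", "only" and "open" are said of these compounds alone.

In a functional assay on the whole organism with Rattus norvegicus as the target (a higher number here means that more compound is needed for the effect, a lower number that less compound is needed), compound 1 `Cn1c(=N)sc2cc(OC(F)(F)F)ccc21` gives 5 mg/kg, and compound 2 `CCCCn1c(=N)sc2cc(OC(F)(F)F)ccc21` gives 10 mg/kg. Compound 3 `N=c1sc2cc(OC(F)(F)F)ccc2n1Cc1ccccc1` gives > 10 mg/kg in this assay. That value is a limit and not a number, so compound 3 has no exact place on the scale.

Compound 4 `N=c1sc2cc(OC(F)(F)F)ccc2n1CC(=O)O` keeps the shared core but changes the group on the chain: carboxy in place of phenyl on a saturated chain carbon bound to an aromatic nitrogen. In words, carboxy stands in place of phenyl on a saturated chain carbon bound to an aromatic nitrogen. Cut one bond further out, the same change reads benzyl to carboxymethyl.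

The measured steps at this place are the best available guide, though none of them introduces a carboxy group. The first is a 2.0-fold higher number from compound 1 to compound 2 (0.30 log units; within the scatter). The second is an at least 2.0-fold higher number from compound 1 to compound 3 (0.30 log units; that floor lies within the scatter). From the compounds shown here alone, the third is a number no lower from compound 2 to compound 3 (the limit leaves the size open), so its size stays open. None of these steps shows a lower number, so no drop in the dose is expected here. The expected step is a step that the limit leaves unreadable from compound 3 to compound 4, which is a cautious estimate given that its starting point is only a limit. For compound 4 the estimated dose is 15 mg/kg, with an expected range from 6 mg/kg to 40 mg/kg.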

Compound 4, dose for half-maximal effect: > 10 mg/kg
Compound 4: only a limit was reported; the forecaster's own chance of this, stated with the estimate: 60%; the middle value does not contradict the limit.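

Among these compounds, with the carboxy group on the saturated chain carbon, compound 4 also ends in a limit and not a number in this assay, so phenyl is not the only group at this place to give such a result. From the compounds shown here alone, the two readable comparisons are an at least 2.0-fold higher number from compound 1 to compound 4 (0.30 log units; that floor lies within the scatter) and a number no lower from compound 2 to compound 4 (the limit leaves the size open), and how far the real gap extends in either case stays open. The other step to compound 4 cannot be read, and swapping phenyl for carboxy shows no order between compound 3 and compound 4, since both results stop at the same point: the limit of > 10 mg/kg in this assay, at which 2 of the 4 values shown sit.

The compounds shown leave open what dose compound 3 and compound 4 really need, and so whether benzyl and carboxymethyl differ at all. They also leave open whether an amine, an ester or a longer chain on this chain carbon would give an exact number, and where such a number would fall relative to compound 1 and compound 2.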